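Cytotoxicity notes: the step from compound 3 to compound 4

The source may hold more compounds than are shown below. What is called first, only, known or untested is meant among the compounds shown, and "the series" means these compounds.

Measured compounds and their values:
- compound 1 `CCCNc1nc(N)nc2c1ncn2/C=C1/CC1(CO)CO`: in an ADME assay on BCBL1 cells (Homo sapiens) for cytotoxicity, with a stated time of 7 days (a higher number here means that more compound is tolerated, a lower number that less compound is tolerated), compound 1 gives only the assay limit > 20000 nM
- compound 2 `Nc1nc(OCC(F)(F)F)c2ncn(/C=C3/CC3(CO)CO)c2n1`: in this assay compound 2 gives only the assay limit > 20000 nM
- compound 3 `COCCOc1nc(N)nc2c1ncn2/C=C1/CC1(CO)CO`: in this assay compound 3 gives only the assay limit > 20000 nM

Compound 3 therefore stands at the top of what this assay can report, and every measured value of the series sits at the same limit (the limit of > 20000 nM in this assay, at which 3 of the 3 values shown sit). The steps that touch compound 3 are a step that the two limits leave unreadable from compound 1 to compound 3 and a step that the two limits leave unreadable from compound 2 to compound 3; the third measured step, a step that the two limits leave unreadable from compound 1 to compound 2, is likewise unreadable. Among the measured compounds shown here, no measured step thus gives a readable size.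

The next compound is compound 4 `CNc1nc(N)nc2c1ncn2/C=C1/CC1(CO)CO`. The change from compound 3 is methylamino in place of 2-methoxyethoxy on an aromatic carbon. Since all three measured values sit at the limit and none of the steps is readable, no step beyond the scatter is expected in this assay in either direction; the most likely outcome is a further limit. Compound 4 is estimated to give 20000 nM, with a range from 10000 nM to 60000 nM. The step this estimate means is expected to be a number no higher from compound 3 to compound 4 (the limit leaves the size open).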

Compound 4, half-maximal cytotoxic concentration: 67000 nM
Estimate against measurement, compound 4: 3.4-fold (0.53 log units) below; the measured number lies above the stated range.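

Compound 4 gives a number, but its steps from compound 1, compound 2 and compound 3 cannot be read, since those three compounds give only an assay limit: the limit of > 20000 nM in this assay, at which 3 of the 4 values shown sit.

In this assay the compounds shown leave open how far compound 1, compound 2 and compound 3 actually lie from compound 4.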